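The source may report more compounds than this note shows. Statements on the series, on what has been measured and on what is new or still open speak of the compounds shown alone.

Among the compounds with values here, compound 1 `CCOC(=O)c1c(C)nc(-c2cccc(C#N)c2)n1O` gives 17600 nM in a functional assay on a cell-free system (plasma, Oryctolagus cuniculus) for inhibition, with stated times of 5 min, 1 min and 6 min (on this read-out lower numbers stand for stronger inhibition and higher numbers for weaker inhibition), the highest of the three numbers measured so far. Compound 2 `CCOC(=O)c1c(C)nc(-c2cccc(C#N)c2)n1OC(C)C` gives 6740 nM and compound 3 `CCOC(=O)c1c(C)nc(-c2cccc(C#N)c2)n1OCc1ccccc1` gives 5930 nM. Compound 4 `CCOC(=O)c1c(C)nc(-c2cccc(C#N)c2)n1OCc1ccccc1Cl` differs from compound 1 in one place: 2-chlorobenzyl in place of hydrogen on an oxygen on an aromatic ring. Within the data shown here, the steps that bear on this change are a 2.6-fold lower number from compound 1 to compound 2 (0.42 log units; beyond the scatter) and a 3.0-fold lower number from compound 1 to compound 3 (0.47 log units; beyond the scatter), both modest yet beyond the scatter, while a 1.1-fold lower number from compound 2 to compound 3 (0.06 log units; within the scatter) lies within it. Each replacement of the hydrogen on that oxygen by a larger group has lowered the number, so a similar modest drop is expected for compound 4, near the benzyl case of compound 3 with 5930 nM. Compound 4 is therefore estimated at 4500 nM, within 2000 nM to 10000 nM, and a step of a 3.9-fold lower number from compound 1 to compound 4 (0.59 log units; beyond the scatter) is expected.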

Compound 4, half-maximal inhibitory concentration: 8710 nM
Compound 4: middle estimate off by 1.9-fold (0.29 log units), on the low side; measured number inside the range.
By their numbers in this assay, from the lowest: compounds 3, 2 and 4 (each within the scatter of the next); then compound 1.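

In this assay the 2-chlorobenzyl group on the oxygen still gives a lower number than hydrogen (a 2.0-fold lower number from compound 1 to compound 4 (0.31 log units; beyond the scatter)), so all three groups placed there so far go the same way. Chloro in place of hydrogen on an aromatic carbon gives no readable change (a 1.5-fold higher number from compound 3 to compound 4 (0.17 log units; within the scatter)), and 2-chlorobenzyl cannot be told apart from isopropyl (a 1.3-fold higher number from compound 2 to compound 4 (0.11 log units; within the scatter)), as both steps lie within the scatter. Nothing available explains these numbers. Going by these compounds, whether an amine or a carboxylic acid on this oxygen substituent, or a longer chain, would move the number further remains open.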